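Fluoro-to-hydrogen step on a fused quinazoline-type core, two side chains

A few compounds are considered here, and "the series" means these few. Any claim that something is new, unique, unknown or untested is made for them only; others in the source may bear on it.

Compound 1 `Fc1ccc2nc(NCCCCN3CCN(c4cccc(Cl)c4Cl)CC3)nc(NCc3ccco3)c2c1` and compound 2 `Clc1cccc(N2CCN(CCCCNc3nc(NCc4ccco4)c4ccccc4n3)CC2)c1Cl` share one core and one side chain and differ in a single place, (hydrogen in place of fluoro on an aromatic carbon). In a functional assay on DU-145 cells (Homo sapiens) for cytotoxicity, read by MTT assay, with a stated time of 2 days (on this read-out lower numbers stand for stronger inhibition and higher numbers for weaker inhibition), compound 1 gives 670 nM, while compound 2 gives 3870 nM; the step of a 5.8-fold higher number from compound 1 to compound 2 (0.76 log units; beyond the scatter) is therefore a modest loss.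

Compound 3 `CCN(CC)CCNc1nc(NCc2ccco2)c2cc(F)ccc2n1` carries a different side chain on the same kind of core; the difference between the two cores is not broken down here. In this assay the result for compound 3 is recorded as "not determined" (no result reported), so no number anchors this side of the series.

Compound 4 `CCN(CC)CCNc1nc(NCc2ccco2)c2ccccc2n1` differs from compound 3 by hydrogen in place of fluoro on an aromatic carbon. The place is described word for word as for the first pair, so this is the same change. Within the data shown here, for compound 4 the only guide is the measured loss from compound 1 to compound 2; with no value for compound 3, the expected figure in this assay for compound 4 is 8000 nM, with an expected range from 1500 nM to 40000 nM.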

Compound 4, half-maximal inhibitory concentration: > 100000 nM
Compound 4 ended at the assay's limit (the forecaster's own chance of this, stated with the estimate: 35%); middle value at least 12-fold (1.09 log units) from the limit.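

In this assay compound 4 gives > 100000 nM, which is a limit of the assay and not a number. Among these compounds, compound 3 has no single number there, so no step from compound 3 to compound 4 can be read. Still open, as far as these compounds go, is whether hydrogen in place of fluoro, with the side chain of compound 3, matches the step between compound 1 and compound 2.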